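The source may hold more compounds than are shown below. What is called first, only, known or untested is meant among the compounds shown, and "the series" means these compounds.

Measured in a functional assay on LNCaP cells (Homo sapiens) for antiproliferative activity; on this read-out lower numbers stand for stronger inhibition and higher numbers for weaker inhibition:
- compound 1 `CNC(=O)C[C@@H]1C[C@@H](c2ccc(Cl)c(Cl)c2)[C@H](NC(=O)c2cc(-c3c(Cl)cnn3C)c(Cl)o2)CN1`: 40 nM
- compound 2 `Cn1ncc(Cl)c1-c1cc(C(=O)N[C@@H]2CN[C@H](CC(O)CO)C[C@H]2c2ccc(Cl)c(Cl)c2)oc1Cl`: 70 nM
- compound 3 `Cn1ncc(Cl)c1-c1cc(C(=O)N[C@@H]2CN[C@H](CCCO)C[C@H]2c2ccc(Cl)c(Cl)c2)oc1Cl`: 210 nM

Compound 3 carries the highest number of the three in this assay. Its two neighbours both lie beyond the scatter from it: a 5.3-fold higher number from compound 1 to compound 3 (0.72 log units; beyond the scatter), and a 3.0-fold higher number from compound 2 to compound 3 (0.48 log units; beyond the scatter).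

Compound 4 `Cn1ncc(Cl)c1-c1cc(C(=O)N[C@@H]2CN[C@H](CCn3cncn3)C[C@H]2c2ccc(Cl)c(Cl)c2)oc1Cl` keeps the core of compound 3 and alters only the end of the chain: 1H-1,2,4-triazol-1-yl in place of hydroxymethyl on a saturated chain carbon, two bonds along the chain from a saturated ring carbon.

Within the data shown here, no measured step makes this replacement, so the evidence is indirect. All three measured steps are changes on this same chain. Two of them are modest, as given above, and the third, a 1.8-fold higher number from compound 1 to compound 2 (0.24 log units; within the scatter), stays within the scatter. Changes here have therefore moved the number only moderately so far, and a large step is not expected for compound 4. The direction is poorly defined. Compound 3 sits at the top of the measured range at 210 nM, which gives a weak expectation of a lower number rather than a higher one.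

The expected change is a 1.8-fold lower number from compound 3 to compound 4 (0.24 log units; within the scatter), and a result within the scatter would be unsurprising. For compound 4 the estimated value is 120 nM, with an expected range of 35 nM to 400 nM.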

Compound 4, half-maximal inhibitory concentration: 60 nM
Compound 4: middle estimate off by 2.0-fold (0.30 log units), on the high side; low and high end bracket the measured number.
By their numbers in this assay, from the lowest: compounds 1, 4 and 2 (each within the scatter of the next); then compound 3.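

In this assay, the end of this chain accepts a five-membered aromatic ring: a 3.5-fold lower number from compound 3 to compound 4 (0.54 log units; beyond the scatter), with 1H-1,2,4-triazol-1-yl in place of hydroxymethyl, and the entering group carries no hydrogen-bond donor, whereas the groups in compound 1 and compound 2 each carry at least one. The other two steps, a 1.2-fold lower number from compound 2 to compound 4 (0.07 log units; within the scatter) and a 1.5-fold higher number from compound 1 to compound 4 (0.18 log units; within the scatter), stay within the scatter, so (1H-1,2,4-triazol-1-yl)methyl, 1,2-dihydroxyethyl and methylcarbamoyl cannot be told apart on this read-out, and among the four compounds only the 2-hydroxyethyl of compound 3 stands apart from the rest. Nothing at hand gives a reason why compound 3 alone stands apart from the others, or why the triazole restores the lower numbers.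

Still open, as far as these compounds go, is whether the ring nitrogens matter or any aromatic ring would serve, which a pyrazol-1-yl, an imidazol-1-yl or a phenyl at the same chain end would help to separate. Equally open, from the compounds shown here alone, are how a longer chain carrying the 1H-1,2,4-triazol-1-yl would read, and how a chain ending in a dimethylamino group or a carboxylic acid would compare.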